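A Cyclohexyl-to-4-Chlorophenyl Swap on the Ring Nitrogen

A few compounds are considered here, and "the series" means these few. Any claim that something is new, unique, unknown or untested is made for them only; others in the source may bear on it.

Measured so far:
Compound 2, `COC(=O)c1nnn([C@@H]2C(=O)N(C3CCCCC3)[C@@H]2/C=C/c2ccccc2)c1C(=O)OC`: -7.7%
Compound 1, `COC(=O)c1nnn([C@@H]2C(=O)N(c3ccc(C)cc3)[C@@H]2/C=C/c2ccccc2)c1C(=O)OC`: "not determined" (no result reported)

For the measured compounds named here, compound 2 holds the only number in a functional assay on KB cells (Homo sapiens) for inhibition, tested at 10 uM; a higher number here means more inhibition of growth at the concentration tested, a lower number less inhibition of growth; compound 1 carries no result there. Compound 3, `COC(=O)c1nnn([C@@H]2C(=O)N(c3ccc(Cl)cc3)[C@@H]2/C=C/c2ccccc2)c1C(=O)OC`, differs from compound 2 by 4-chlorophenyl in place of cyclohexyl on an amide-type nitrogen in a ring. Going by the values given here, no step between two measured compounds exists, so nothing shows how a change of this kind shifts growth inhibition, and the step from compound 2 to compound 3 is expected to stay within the usual scatter, leaning slightly upward. Compound 3 is therefore expected to give about 3%, within a range of -12% to 25%, an expected step of a number 10.7 percentage points higher from compound 2 to compound 3 (beyond the scatter).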

Compound 3, percent growth inhibition at one concentration: 19.5%
Estimate against measurement, compound 3: 16.5 percentage points below, within the range that was stated.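

In this assay, for the compounds shown here, the change to 4-chlorophenyl in place of cyclohexyl gives a number 27.2 percentage points higher from compound 2 to compound 3 (beyond the scatter) and is the first readable step at this position. It shows that the group on this amide-type nitrogen in a ring can shift growth inhibition by more than ordinary assay variation. Nothing available explains why the shift occurs.

The compounds shown do not separate the effect of the aromatic ring from that of the chlorine. As far as these compounds go, how a plain phenyl or a 4-methoxyphenyl group would behave on this nitrogen remains open.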